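Bromo for hydrogen on the fused ring: compound 3

The source may hold more compounds than are shown below. What is called first, only, known or untested is meant among the compounds shown, and "the series" means these compounds.

Measured so far:
compound 1 `O=c1oc2ccc(Cl)cc2cc1-c1cn2nc(-c3c([O-])[o+]nn3-c3ccc(Cl)cc3)sc2n1` — > 80 ug/mL (a limit)
compound 2 `O=c1oc2ccccc2cc1-c1cn2nc(-c3c([O-])[o+]nn3-c3ccc(Cl)cc3)sc2n1` — > 80 ug/mL (a limit)

In a functional assay on HT-29 cells (Homo sapiens) for cytotoxicity, read by sulforhodamine B assay (on this read-out lower numbers stand for higher toxicity in this test and higher numbers for lower toxicity in this test), compound 1 gives > 80 ug/mL, which is a limit and not a number. Compound 2 gives > 80 ug/mL in this assay, again a limit rather than a number. Both results rest on (the limit of > 80 ug/mL in this assay, at which 2 of the 2 values shown sit), so the step that the two limits leave unreadable from compound 1 to compound 2 cannot be sized; it consists of hydrogen in place of chloro on an aromatic carbon. Compound 2 thus stands at the limit of this assay only, with no number of its own.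

Compound 3 `O=c1oc2ccc(Br)cc2cc1-c1cn2nc(-c3c([O-])[o+]nn3-c3ccc(Cl)cc3)sc2n1` differs from compound 2 by bromo in place of hydrogen on an aromatic carbon. Going by the values given here, the only measured step, from compound 1 to compound 2, touches the same place but runs between two limits, so its size and direction are unreadable. Among the compounds with values here, no measured step therefore bears on compound 3 in a way that fixes a size, and no shift beyond the scatter can be argued in either direction.

The step that the limit leaves unreadable from compound 2 to compound 3 is expected to be unreadable as well. Compound 3 is estimated at 100 ug/mL in this assay, with a range from 50 ug/mL to 200 ug/mL, most likely reported as a limit.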

Compound 3, concentration lethal to 50% of the cells: > 70 ug/mL
Compound 3 gave a limit, no number (the forecaster's own chance of this, stated with the estimate: 75%); the middle value is on the limit's open side.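

In this assay compound 3 gives > 70 ug/mL, which is a limit and not a number. The steps from compound 1 and from compound 2 to compound 3 therefore cannot be read, and this result rests on: the limit of > 70 ug/mL in this assay, at which 1 of the 3 values shown sits.

The compounds shown leave open whether hydrogen, chloro or bromo on this aromatic carbon shifts the read-out in this assay at all, and in which direction.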